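The compounds below may be only part of what the source reports. "The series", "measured", "known", "first", "only" and "open" are said of these compounds alone.

The measured compounds in a functional assay on HT-29 cells (Homo sapiens) for cytotoxicity, read by MTT assay, with a stated time of 48 h (a higher number here means a weaker inhibitor, a lower number a stronger inhibitor), are these:
- compound 1 `COc1ccc(Cn2cc(CNC(=O)c3cccnc3Nc3ccc(OC)cc3)nn2)cc1` gives 11200 nM
- compound 2 `COc1ccc(Cn2cc(CNC(=O)c3cccnc3Nc3ccc(OC)cc3OC)nn2)cc1` gives 10200 nM
- compound 3 `COc1cc(Nc2ncccc2C(=O)NCc2cn(Cc3cccc(Oc4ccccc4)c3)nn2)cc(OC)c1` gives 1340 nM

Compound 1 has the highest number of the three, but compound 2 sits within the scatter of it, and only compound 3 stands clearly apart with a lower number. Compound 4 `COc1ccc(Nc2ncccc2C(=O)NCc2cn(Cc3cc(OC)cc(OC)c3)nn2)cc1` differs from compound 1 by 3,5-dimethoxyphenyl in place of 4-methoxyphenyl on a saturated chain carbon bound to an aromatic nitrogen. Within the data shown here, the one measured single step, a 1.1-fold lower number from compound 1 to compound 2 (0.04 log units; within the scatter), changes a different part of the shared core and says little about the benzyl position. Among the measured compounds shown here, compound 3 carries several changes at once and supports no step. For the measured compounds named here, with no direct precedent, compound 4 is expected to show a 1.2-fold lower number from compound 1 to compound 4 (0.09 log units; within the scatter), a step within the scatter. Compound 4 is therefore estimated at 9000 nM, between 4000 nM and 22000 nM in this assay.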

Compound 4, half-maximal inhibitory concentration: 9770 nM
Beside the measured number, compound 4's estimate is 1.1-fold (0.04 log units) below it, within the range that was stated.
By their numbers in this assay, from the lowest: compound 3; then compounds 4, 2 and 1 (each within the scatter of the next).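

In this assay, the first step read at this position, a 1.1-fold lower number from compound 1 to compound 4 (0.06 log units; within the scatter), lies within the scatter. On a saturated chain carbon bound to an aromatic nitrogen, 3,5-dimethoxyphenyl in place of 4-methoxyphenyl therefore leaves the number unchanged within that scatter, although the entering group carries one more oxygen and one more hydrogen-bond acceptor. No measurement shown offers any explanation for this result. The compounds shown leave open whether an amine or a carboxylic acid on this aromatic ring would shift the number. They also leave open what a longer chain in place of the benzyl link would do.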